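A Linker Swap on Compound 1, Awaiting Measurement

The source may hold more compounds than are shown below. What is called first, only, known or untested is meant among the compounds shown, and "the series" means these compounds.

Compound 1 `Nc1cc(N)c2nc(-c3ccccc3)c(Oc3ccc(Cl)c(Cl)c3)nc2c1`: 20000 nM
Compound 2 `CCOC(=O)[C@H](CCC(=O)O)NC(=O)c1ccc(CNc2nc3cc(N)cc(N)c3nc2-c2ccccc2)cc1`: 47900 nM
Compound 3 `CCOC(=O)[C@H](CCC(=O)O)NC(=O)c1ccc(Oc2nc3cc(N)cc(N)c3nc2-c2ccccc2)cc1`: 34700 nM

In a functional assay on HCT-15 cells (Homo sapiens) for inhibition, read by sulforhodamine B assay, with a stated time of 48 h (a lower number here means a stronger inhibitor of growth, a higher number a weaker inhibitor of growth), compound 1 gives 20000 nM, the lowest of the three numbers. Compound 3 lies within the usual scatter of that result, whereas compound 2 lies beyond it. All three are weak inhibitors of growth. Compound 4 `Nc1cc(N)c2nc(-c3ccccc3)c(NCc3ccc(F)cc3)nc2c1` differs from compound 1 in one place: (4-fluorobenzyl)amino in place of 3,4-dichlorophenoxy on an aromatic carbon. Among the compounds with values here, no pair of measured compounds differs in only that place, so there is no direct step to lean on. Given that compound 2 gives 47900 nM and compound 3 gives 34700 nM in this assay, no step beyond the scatter is expected in either direction. Compound 4 is therefore estimated at 30000 nM, between 10000 nM and 90000 nM, an expected step of a 1.5-fold higher number from compound 1 to compound 4 (0.18 log units; within the scatter).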

Compound 4, concentration for 50% growth inhibition: 3310 nM
The estimate for compound 4 lay 9.1-fold (0.96 log units) above the measured number; measured number below the stated range.
By their numbers in this assay, from the lowest: compound 4; then compounds 1, 3 and 2 (each within the scatter of the next, the first and the last beyond it).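

In this assay, this position proves sensitive to the group it carries: (4-fluorobenzyl)amino in place of 3,4-dichlorophenoxy gives a 6.0-fold lower number from compound 1 to compound 4 (0.78 log units; beyond the scatter). The entering group carries a hydrogen-bond donor that the leaving group lacks, and each holds one six-membered aromatic ring of carbon only. No measurement here explains the step. On these data alone, the change alters both the link and the ring substituents, so the source of the step remains open. A 4-fluorophenoxy group or a (3,4-dichlorobenzyl)amino group at this carbon would separate the two.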